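This account rests on a few compounds, and the source may have more. Where it says the series, first, only, none or still open, it means among the compounds named here.

Compound 1, `CC(=O)O[C@@H]1OC(=O)[C@](C)(C(C)=O)[C@@H]1C`, gives 6000 nM in a functional assay on MCF7 cells (Homo sapiens) for cytotoxicity, read by MTT assay; a higher number here means a weaker inhibitor, a lower number a stronger inhibitor.
Compound 2, `CC(=O)O[C@@H]1OC(=O)[C@](C)(C(C)=O)[C@@H]1C(C)C`, gives only > 50000 nM, a limit of the assay.
Compound 3, `CC(=O)O[C@@H]1OC(=O)[C@@](C)(C(C)=O)[C@@H]1C`, gives only > 10000 nM, again a limit of the assay.

Of the three, only compound 1 has a true number. As far as these compounds go, compound 3 stands at a limit (the limit of > 10000 nM in this assay, at which 1 of the 3 values shown sits), so where it lies beyond that is unknown. Compound 2 sits at a still higher limit (the limit of > 50000 nM in this assay, at which 1 of the 3 values shown sits). The step of an at least 8.3-fold higher number from compound 1 to compound 2 (0.92 log units; beyond the scatter) shows that a larger group on that ring carbon weakens the inhibitor. The step of an at least 1.6-fold higher number from compound 1 to compound 3 (0.22 log units; that floor lies within the scatter) rests on two compounds that differ only in configuration as drawn (the fact that compounds 1 and 3 differ only in the configuration as drawn), and its floor lies within the scatter.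

Compound 4, `CC(=O)O[C@@H]1OC(=O)[C@@](O)(C(C)=O)[C@@H]1C`, differs from compound 3 by hydroxy in place of methyl on a saturated ring carbon. Among the compounds with values here, no measured step swaps a methyl for a hydroxy group at that carbon, so nothing here speaks directly to this change. With compound 3 already at a limit, the estimated step that the limit leaves unreadable from compound 3 to compound 4 is expected to be none beyond the scatter. Compound 4 is therefore estimated at 20000 nM, within a range from 5000 nM to 80000 nM, most likely again reported only as a limit.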

Compound 4, half-maximal inhibitory concentration: > 50000 nM
Compound 4 gave a limit, no number; the forecaster's own chance of this, stated with the estimate: 60%; middle value at least 2.5-fold (0.39 log units) away from the limit.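

Compound 3 and compound 4 both give only limits in this assay, not true numbers, so the step between them cannot be read. The compounds shown leave open whether hydroxy in place of methyl on that saturated ring carbon changes the result at all, and how far beyond its limit each compound lies.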